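Adding a Second Chloro to the Benzyloxy Ring

A few compounds are considered here, and "the series" means these few. Any claim that something is new, unique, unknown or untested is made for them only; others in the source may bear on it.

Compound 1 `Cc1ccc(-c2nn(-c3ccccc3)cc2C(=O)NOCc2ccccc2)cc1` gives 1870 nM in a functional assay on MCF7 cells (Homo sapiens) for antiproliferative activity, read by MTT assay, with a stated time of 48 h, in the presence of a further agent that is not named here; on this read-out lower numbers stand for stronger inhibition of growth and higher numbers for weaker inhibition of growth. Compound 2 `Cc1ccc(-c2nn(-c3ccccc3)cc2C(=O)NOCc2ccccc2Cl)cc1`, which differs by chloro in place of hydrogen on an aromatic carbon, gives 2640 nM in this assay, a step of a 1.4-fold higher number from compound 1 to compound 2 (0.15 log units; within the scatter). Compound 3 `O=C(NOCc1ccccc1Cl)c1cn(-c2ccccc2)nc1-c1ccc(Cl)cc1` gives 16100 nM in this assay, a step of a 6.1-fold higher number from compound 2 to compound 3 (0.79 log units; beyond the scatter). Compound 4 `O=C(NOCc1ccc(Cl)cc1Cl)c1cn(-c2ccccc2)nc1-c1ccc(Cl)cc1` has not yet been measured; it differs from compound 3 by chloro in place of hydrogen on an aromatic carbon. This is the same kind of change as from compound 1 to compound 2, but the place differs: there the chloro entered ortho to a large group, here it enters meta to a chloro group and para to a large group. The difference between the two cores is not broken down here. Because the earlier step was a 1.4-fold higher number from compound 1 to compound 2 (0.15 log units; within the scatter), the step from compound 3 to compound 4 is expected to be a 1.2-fold higher number from compound 3 to compound 4 (0.09 log units; within the scatter). Compound 4 is therefore estimated at 20000 nM in this assay, within 9000 nM to 45000 nM.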

Compound 4, concentration for 50% growth inhibition: 16200 nM
Compound 4: the middle estimate sits 1.2-fold (0.09 log units) above what was measured; the range from low to high includes it.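

In this assay the change from 2-chlorobenzyl to 2,4-dichlorobenzyl is a 1.0-fold higher number from compound 3 to compound 4 (0.00 log units; within the scatter) and so, like the earlier step, lies within the scatter. Set side by side, the two steps show no difference between the cores: the same change on two cores in this assay, a 1.4-fold higher number (0.15 log units; within the scatter) from compound 1 to compound 2 and a 1.0-fold higher number (0.00 log units; within the scatter) from compound 3 to compound 4, 1.4-fold (0.15 log units) apart, within the scatter of two such steps. Going by these compounds alone, this does not show that one placement carries from core to core, since the chloro enters a different place in each step and only two cores are compared. The compounds shown leave open how the benzyl ring would respond to a methoxy group or an amine in place of the added chloro. Among them, the 2,4-dichlorobenzyl group stands only on the core of compound 3, so its effect on the core of compound 1 also remains open.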